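Replacing a Pyridine with an Oxane: Solubility Outlook

This account rests on a few compounds, and the source may have more. Where it says the series, first, only, none or still open, it means among the compounds named here.

Compound 3 `CNC(=O)c1cc(C(=O)N[C@H]2[C@@H]3COC[C@@H]32)cc2c1OC[C@H]2c1ccccn1` is one of three measured compounds that share a core and differ only in the group on a saturated ring carbon. In a physicochemical assay for solubility (on this read-out higher numbers stand for higher solubility and lower numbers for lower solubility), compound 3 gives >= 158 ug/mL, which is a limit of the assay rather than a number. Compound 1 `CNC(=O)c1cc(C(=O)N[C@H]2[C@@H]3COC[C@@H]32)cc2c1OC[C@H]2c1ccccc1` carries phenyl at that position. In this assay compound 1 gives >= 165 ug/mL, also a limit. Compound 2 `CNC(=O)c1cc(C(=O)N[C@H]2[C@@H]3COC[C@@H]32)cc2c1OC[C@H]2c1cccc(OC)c1` carries 3-methoxyphenyl there. In this assay compound 2 gives >= 186 ug/mL, again a limit. All three values sit at limits, so the steps among them cannot be sized: a step that the two limits leave unreadable from compound 1 to compound 2, a step that the two limits leave unreadable from compound 1 to compound 3 and a step that the two limits leave unreadable from compound 2 to compound 3.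

Compound 4 `CNC(=O)c1cc(C(=O)N[C@H]2[C@@H]3COC[C@@H]32)cc2c1OC[C@H]2C1CCOCC1` differs from compound 3 by oxan-4-yl in place of pyridin-2-yl on a saturated ring carbon. Among the compounds with values here, none of the measured steps gives a readable size, so no direction can be taken from them; the three limits (the limit of >= 158 ug/mL in this assay, at which 1 of the 3 values shown sits), the limit of >= 165 ug/mL in this assay, at which 1 of the 3 values shown sits, and the limit of >= 186 ug/mL in this assay, at which 1 of the 3 values shown sits, show only that every measured member sits at the upper edge of what this assay reports. For compound 4 the expected value in this assay is 200 ug/mL, within 100 ug/mL to 400 ug/mL. The expected step is a step that the limit leaves unreadable from compound 3 to compound 4, most likely ending at a limit once more.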

Compound 4, solubility: >= 177 ug/mL
Compound 4 ended at the assay's limit; the forecaster's own chance of this, stated with the estimate: 70%; the middle value does not contradict the limit.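

Compound 4, like compound 1, compound 2 and compound 3, sits at a limit in this assay, so the steps from those three to compound 4 cannot be read. The compounds shown leave open whether changing the group on the saturated ring carbon alters solubility at all.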